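This account rests on a few compounds, and the source may have more. Where it says the series, first, only, none or still open, it means among the compounds named here.

Compound 1, `O=C(C(c1ccccc1)c1ccccc1)N1CCN(CCCn2c(=O)[nH]c3ccccc32)CC1`, gives 7800 nM in an assay on RPMI-8226 cells for antagonist activity at P2X purinoceptor 7 (Homo sapiens), read by calcium flux; a higher number here means a weaker inhibitor, a lower number a stronger inhibitor.
Compound 2, `O=c1[nH]c2ccccc2n1CCCCN1CCN(C(c2ccccc2)c2ccccc2)CC1`, gives 180 nM in this assay.

Among the measured compounds shown here, of these two numbers, the one for compound 2 is the lower, and the gap to compound 1 lies beyond the scatter; compound 2 therefore stands as the stronger inhibitor of the pair in this assay. For the measured compounds named here, the two measured compounds differ in more than one place, so no single step between them can be drawn.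

The unmeasured compound 3, `Fc1ccc2ccn(CCCCN3CCN(C(c4ccccc4)c4ccccc4)CC3)c2c1`, differs from compound 2 in one place only: a group of 10 heavy atoms (8 carbon, 1 nitrogen, 1 fluorine; one five-membered aromatic ring with 1 hetero atom, one six-membered aromatic ring of carbon only) in place of a group of 10 heavy atoms (7 carbon, 2 nitrogen, 1 oxygen; one five-membered aromatic ring with 2 hetero atoms, one six-membered aromatic ring of carbon only), on a saturated chain carbon, four bonds along the chain from an amine nitrogen in a ring. Going by the values given here, no measured pair shows this change, so its effect can only be guessed from the measured values themselves. Because compound 2 gives 180 nM and the entering group gives up the hydrogen-bond donor of the leaving group, a modest loss is expected, with a step of a 2.8-fold higher number from compound 2 to compound 3 (0.44 log units; beyond the scatter) that may well stay close to the scatter. Compound 3 is accordingly expected to give about 500 nM in this assay, within a range from 100 nM to 3000 nM.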

Compound 3, half-maximal inhibitory concentration: 110 nM
Estimate against measurement, compound 3: 4.5-fold (0.66 log units) above; the measured number falls inside the stated range.
By their numbers in this assay, from the lowest: compounds 3 and 2 (each within the scatter of the next); then compound 1.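

In this assay, the exchange of the leaving group for 6-fluoro-1H-indol-1-yl is a 1.6-fold lower number from compound 2 to compound 3 (0.21 log units; within the scatter), so the two compounds cannot be told apart in this read-out. Among the compounds shown here, this is the first single-place step available, and it shows that at this place, on a saturated chain carbon, four bonds along the chain from an amine nitrogen in a ring, the group can go from 1 hydrogen-bond donor to 0 hydrogen-bond donors, and can lose its double bond outside aromatic rings, with no difference beyond the scatter, a reading that rests on this one pair alone. Nothing measured here accounts for this outcome.

What stays open is whether the fluorine counts for anything on its own, since the compounds shown do not separate it from the rest of the exchange: a 1H-indol-1-yl group without fluorine, or one with chlorine or a methoxy group in its place, would address that. Also open, as far as these compounds go, is how a longer chain, or an amine or a carboxylic acid at this place, would read in this assay.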